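Swapping the Ring on the Core Nitrogen

The compounds below may be only part of what the source reports. "The series", "measured", "known", "first", "only" and "open" are said of these compounds alone.

Of the compounds shown here, two have been measured in a functional assay (B cells) with Mus musculus as the target; a higher number here means that more compound is needed for the effect, a lower number that less compound is needed. Compound 1 `C=CCn1c(=O)n(C2CCC(CO)C2)c2nc(N)nc(O)c21` gives 226 uM, the highest of the two numbers; compound 2 `Cn1c(=O)n([C@@H]2O[C@H](CO)[C@H]3OC(C)(C)O[C@H]32)c2nc(N)nc(O)c21` gives 168 uM, within the scatter of compound 1. Compound 3 `C=CCn1c(=O)n(C2C=CC(CO)O2)c2nc(N)nc(O)c21` has not been measured. It differs from compound 1 in one place: a group of 7 heavy atoms (5 carbon, 2 oxygen; one five-membered non-aromatic ring with 1 hetero atom) in place of a group of 7 heavy atoms (6 carbon, 1 oxygen; one five-membered non-aromatic ring of carbon only), on an aromatic nitrogen. Within the data shown here, no measured pair shows such a change, so nothing beyond the scatter can be predicted; a step of about the size of the scatter, in either direction, is expected, a 1.1-fold lower number from compound 1 to compound 3 (0.05 log units; within the scatter). Compound 3 is therefore estimated at 200 uM, with a range from 60 uM to 650 uM.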

Compound 3, concentration for half-maximal effect: 6 uM
The estimate for compound 3 lay 33-fold (1.52 log units) above the measured number, outside the stated range (below it).
By their numbers in this assay, from the lowest: compound 3; then compounds 2 and 1 (each within the scatter of the next).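

In this assay, among these compounds, the group on the aromatic nitrogen matters far more than the earlier compounds could show: the five-membered ring with one hetero atom and a double bond, in place of the all-carbon ring, gives a 38-fold lower number from compound 1 to compound 3 (1.58 log units; beyond the scatter) with the allyl group unchanged. So a change that leaves the count of heavy atoms in the group the same can still produce a large step. No measurement shown explains why the number drops this far.

The ring oxygen and the double bond enter together, so their shares of the step remain unseparated. Also open, on these data alone, is whether a saturated ring with that oxygen, or a ring with sulfur in its place, would give a similar number.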